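The source may hold more compounds than are shown below. What is called first, only, known or untested is meant among the compounds shown, and "the series" means these compounds.

Measured compounds, single-concentration agonist read-out:

compound 1 `NNC(=O)c1c(N)sc2c1CCCCCC2`: 48%
compound 2 `Nc1sc2c(c1C(=O)NNc1ccccc1)CCCCC2`: 42%
compound 3 `Nc1sc2c(c1C(=O)NCc1cccc(Cl)c1)CCCCCC2`: 47%

All three numbers come from a functional assay on CHO cells for agonist activity at adenosine receptor A1 (Homo sapiens), read by ERK phosphorylation, tested at 10 uM; a lower number here means a weaker effect, a higher number a stronger effect of the compound at the concentration tested. Compound 1 gives the highest of the three numbers, but its gap to compound 3 and its gap to compound 2 both lie within the usual scatter of this kind of measurement, so the three compounds read as one level and no ranking between them is claimed.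

The step considered here goes from compound 1 to compound 4 `NC(=O)c1c(N)sc2c1CCCCCC2`, not yet measured in this assay. The change is hydrogen in place of amino on an amide-type nitrogen whose other neighbour is the carbonyl carbon, which turns the aminocarbamoyl group into a carbamoyl group.

Within the data shown here, no measured pair differs in one place, so nothing here shows how large such a change tends to be. With the three measured numbers sitting at one level, the expectation for this assay is a step of no clear direction, not beyond the scatter, and a wide range is kept. Compound 4 is expected to give 42%, between 25% and 60%, which as an expected step reads a number 6 percentage points lower from compound 1 to compound 4 (within the scatter).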

Compound 4, a percentage reported as activity, at one concentration (the size of the read-out at that concentration, not a potency): 48%
Beside the measured number, compound 4's estimate is 6 percentage points below it, and the stated range covers the measured number.
By their numbers in this assay, from the lowest: compounds 2, 3, 1 and 4 (each within the scatter of the next).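

In this assay, among these compounds, hydrogen in place of amino on the amide-type nitrogen gives no change at the digits printed from compound 1 to compound 4 (within the scatter), the first step that can be read at a single place. For this pair, the aminocarbamoyl and carbamoyl groups therefore read as one level at the concentration tested, so the terminal amino is not required to keep the read-out at this level. No measurement shown here offers an explanation for this result.

Still open, going by these compounds, is whether a methyl or hydroxyl group on this same nitrogen would stay at that level, and whether a carboxylic acid in place of the carbamoyl group would do so. On these data alone, because the read-out comes from one concentration, potency at this position also remains open for compound 1 and compound 4.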